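This account rests on a few compounds, and the source may have more. Where it says the series, first, only, none or still open, it means among the compounds named here.

In a functional assay on L6 cells (Rattus norvegicus) for cytotoxicity (on this read-out higher numbers stand for weaker inhibition and lower numbers for stronger inhibition), three compounds have been tested so far, and none has yet given a number. Compound 1 (`C[C@H](NC(=O)Cn1ccc(=O)[nH]c1=O)C(=O)N[C@@H](CCCCN)C(=O)O`) gives > 243000 nM, which is a limit. Compound 2 (`CC(O)[C@H](NC(=O)[C@H](C)NC(=O)Cn1ccc(=O)[nH]c1=O)C(=O)O`) gives > 262000 nM, also a limit. Compound 3 (`NCCCC[C@H](NC(=O)CNC(=O)Cn1ccc(=O)[nH]c1=O)C(=O)O`) gives > 253000 nM, again a limit, and this is where the next step starts.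

Compound 4 (`CC(O)[C@H](NC(=O)CNC(=O)Cn1ccc(=O)[nH]c1=O)C(=O)O`) differs from compound 3 in one place: 1-hydroxyethyl in place of 4-aminobutyl on a saturated chain carbon bound to an amide-type nitrogen and a carbonyl carbon, with 1-hydroxyethyl in place of 4-aminobutyl on a saturated chain carbon bound to an amide-type nitrogen and a carbonyl carbon.

Within the data shown here, the closest precedent for this exchange is a step that the two limits leave unreadable from compound 1 to compound 2. The other measured change, hydrogen in place of methyl at that kind of carbon, is a step that the two limits leave unreadable from compound 1 to compound 3. Neither gives a size to carry over. Compound 2 already carries the 1-hydroxyethyl group and stays at its limit of > 262000 nM. On that basis, the expected outcome in this assay is no step beyond the scatter in either direction, and the estimated step is a step that the limit leaves unreadable from compound 3 to compound 4. Compound 4 will most likely be reported only as a limit. Compound 4 is estimated at 274000 nM, with an expected range from 150000 nM to 400000 nM.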

Compound 4, half-maximal inhibitory concentration: > 274000 nM
Compound 4: no number, only a limit; the forecaster's own chance of this, stated with the estimate: 93%; the middle value lies on the limit itself.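

In this assay compound 4 gives > 274000 nM, which is a limit, so its steps from compound 3 and from compound 2 cannot be read. The compounds shown leave open what size of step, if any, follows from 1-hydroxyethyl in place of 4-aminobutyl or from hydrogen in place of methyl in this assay.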